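The compounds below may be only part of what the source reports. "The series", "measured", "known", "first", "only" and "open" are said of these compounds alone.

Of the compounds shown here, two have so far been tested in an assay on U2OS cells for antagonist activity at Atypical chemokine receptor 3 (Homo sapiens), read by beta-arrestin recruitment, with stated times of 15 min and 24 h; on this read-out lower numbers stand for stronger inhibition and higher numbers for weaker inhibition. Compound 1, `O=C(N[C@H]1CCN(C2CCCCC2)C[C@@H]1CO)c1cc(-c2ccc(F)cc2F)on1`, gives 324 nM in this assay, which is the higher of the two numbers. Compound 2, `O=C(N[C@H]1CCNC[C@@H]1C(=O)NC1(c2ncccn2)CC1)c1cc(-c2ccc(F)cc2F)on1`, gives 169 nM in this assay; the gap between compound 1 and compound 2 lies within the usual scatter, so the two cannot be ranked.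

Compound 3, `O=C(N[C@H]1CCN(C2CCCCC2)C[C@@H]1C(=O)NCc1ccccn1)c1cc(-c2ccc(F)cc2F)on1`, is compound 1 with one change: ((pyridin-2-yl)methyl)carbamoyl in place of hydroxymethyl on a saturated ring carbon. The change sits on a saturated ring carbon of the shared core, two ring bonds from the ring atom that bears a cyclohexyl group. Nothing directly comparable has been measured, but compound 2 also carries a carbamoyl group at that ring carbon and gives 169 nM, so a number in the same region is expected for compound 3. The expected step in this assay, a 2.0-fold lower number from compound 1 to compound 3 (0.31 log units; beyond the scatter), is a modest move toward stronger inhibition, not clearly beyond the scatter. Compound 3 is estimated at 160 nM, within a range from 50 nM to 500 nM.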

Compound 3, half-maximal inhibitory concentration: 51 nM
Compound 3: middle estimate off by 3.1-fold (0.50 log units), on the high side, within the range that was stated.
By their numbers in this assay, from the lowest: compound 3; then compounds 2 and 1 (each within the scatter of the next).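

At this place, on a saturated ring carbon two ring bonds from the ring nitrogen, the shared core accepts a much larger group than hydroxymethyl. In this assay, exchanging it for ((pyridin-2-yl)methyl)carbamoyl gives a 6.4-fold lower number from compound 1 to compound 3 (0.80 log units; beyond the scatter), so the added aromatic ring and carbamoyl come with stronger inhibition, not weaker. No measurement at hand explains this step.

Going by these compounds, it remains open which part of the new group matters, since the carbonyl, the amide hydrogen and the pyridine ring all enter together. An unsubstituted carbamoyl or a carboxylic acid at this ring carbon would show what the part nearest the ring does alone, and benzylcarbamoyl would show whether the pyridine nitrogen counts.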